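A Fluorine Added to the Fused Ring of Compound 3

The compounds below may be only part of what the source reports. "The series", "measured", "known", "first", "only" and "open" are said of these compounds alone.

Compound 1, `Cc1ccc2nc(NC(=O)c3cn(-c4ccccc4)nc3-c3ccccc3)sc2c1`, was tested in a functional assay on U-87MG ATCC cells for cytotoxicity against U-87 MG (Homo sapiens), read by MTT assay, with a stated time of 72 h (on this read-out lower numbers stand for stronger inhibition and higher numbers for weaker inhibition), where compound 1 gives 23200 nM. Compound 2, `Cc1ccc2nc(NC(=O)c3cn(-c4ccccc4)nc3-c3ccc(F)cc3)sc2c1`, is the same molecule with fluoro in place of hydrogen on an aromatic carbon, (fluoro in place of hydrogen on an aromatic carbon). In this assay compound 2 reaches only a limit, > 50000 nM. The step of an at least 2.1-fold higher number from compound 1 to compound 2 (0.33 log units; beyond the scatter) is therefore a weakening, at least modest. Compound 3, `COc1ccc(-c2nn(-c3ccccc3)cc2C(=O)Nc2nc3ccccc3s2)cc1`, has a different core; how the two cores differ is not broken down here. In this assay compound 3 gives 11500 nM, within the scatter of the number for compound 1.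

Compound 4, `COc1ccc(-c2nn(-c3ccccc3)cc2C(=O)Nc2nc3ccc(F)cc3s2)cc1`, has not been measured. It differs from compound 3 by fluoro in place of hydrogen on an aromatic carbon. This is the same kind of change as in compound 2, yet the place differs: there the fluoro sat para to a large group on a six-membered ring of carbon only; here it sits on a fused system, meta to a fused ring and para to a fused ring. Compound 4 is expected to give about 18000 nM, likely between 7000 nM and 50000 nM. The expected step of a 1.6-fold higher number from compound 3 to compound 4 (0.19 log units; within the scatter) rests on the earlier step of an at least 2.1-fold higher number from compound 1 to compound 2 (0.33 log units; beyond the scatter), tempered by the different place.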

Compound 4, half-maximal inhibitory concentration: 8990 nM
Compound 4: middle estimate off by 2.0-fold (0.30 log units), on the high side; low and high end bracket the measured number.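

In this assay the new step is a 1.3-fold lower number from compound 3 to compound 4 (0.11 log units; within the scatter), so on this core the swap of hydrogen for fluoro leaves compound 3 and compound 4 indistinguishable. Set beside the earlier case, the same swap does not behave as one fixed step that can be carried from one core to another: the same change on two cores in this assay, an at least 2.1-fold higher number (0.33 log units; beyond the scatter) from compound 1 to compound 2 and a 1.3-fold lower number (0.11 log units; within the scatter) from compound 3 to compound 4, at least 2.7-fold (0.44 log units) apart, beyond the scatter of two such steps. Going by these compounds alone, this does not show whether the core or the place of the fluoro sets that gap, since the two pairs differ in both, and each core offers only a single comparison.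

As far as these compounds go, compound 2 gives only a limit, so the true size of the earlier step stays open: the limit of > 50000 nM in this assay, at which 1 of the 4 values shown sits. Also open, from the compounds shown here alone, is whether an amine or a carboxylic acid on the same aromatic carbon would give a number different from the fluoro, and whether the swap of hydrogen for fluoro would follow either pattern on further cores.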